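Shifting the Methyl: Compound 2 to Compound 4

The source may hold more compounds than are shown below. What is called first, only, known or untested is meant among the compounds shown, and "the series" means these compounds.

Measured so far, all in a functional assay on B16-F10 cells (Mus musculus) for inhibition, read by MTT assay, with a stated time of 72 h; a lower number here means a stronger inhibitor, a higher number a weaker inhibitor:
- compound 1 `CC(C)c1ccc(-c2nc(SCc3cn(CC(=O)NC(=O)Nc4ccccn4)nn3)nc(Nc3ccc(F)cc3)c2C#N)cc1` gives 7250 nM
- compound 2 `CC(C)c1ccc(-c2nc(SCc3cn(CC(=O)NC(=O)Nc4ccccn4)nn3)nc(Nc3ccc(Cl)cc3)c2C#N)cc1` gives 860 nM
- compound 3 `Cc1ccc(Nc2nc(SCc3cn(CC(=O)NC(=O)Nc4ccccn4)nn3)nc(-c3ccc(C(C)C)cc3)c2C#N)cc1` gives 3060 nM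

Among these three, compound 2 has the lowest number; the steps of an 8.4-fold lower number from compound 1 to compound 2 (0.93 log units; beyond the scatter) and a 3.6-fold higher number from compound 2 to compound 3 (0.55 log units; beyond the scatter) both place it clearly ahead. Compound 4 `Cc1ccccc1Nc1nc(SCc2cn(CC(=O)NC(=O)Nc3ccccn3)nn2)nc(-c2ccc(C(C)C)cc2)c1C#N` differs from compound 2 by 2-methylphenyl in place of 4-chlorophenyl on a nitrogen on an aromatic ring. Within the data shown here, only one measured step swaps the chloro for a methyl on that ring, a 3.6-fold higher number from compound 2 to compound 3 (0.55 log units; beyond the scatter), and it weakened inhibition by a modest amount; a 2.4-fold lower number from compound 1 to compound 3 (0.37 log units; beyond the scatter) shows methyl also beating fluoro. Among the measured compounds shown here, no measured compound carries 2-methylphenyl here, so the exact size is uncertain, but a modest loss is expected, a 4.7-fold higher number from compound 2 to compound 4 (0.67 log units; beyond the scatter). Compound 4 is therefore estimated at 4000 nM, likely between 1500 nM and 12000 nM.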

Compound 4, half-maximal inhibitory concentration: 18600 nM
The estimate for compound 4 lay 4.7-fold (0.67 log units) below the measured number; the whole stated range lies below it.
By their numbers in this assay, from the lowest: compound 2; then compound 3; then compound 1; then compound 4.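

The position of the methyl on this ring matters, not only which substituent the ring carries: 2-methylphenyl in place of 4-methylphenyl gives a 6.1-fold higher number from compound 3 to compound 4 (0.78 log units; beyond the scatter). Among these compounds, compound 4 also trails the best compound by the largest step so far, a 22-fold higher number from compound 2 to compound 4 (1.34 log units; beyond the scatter). Even the weakest earlier compound stays ahead of it, a 2.6-fold higher number from compound 1 to compound 4 (0.41 log units; beyond the scatter).

Nothing available here explains this loss. Also open, going by these compounds, is whether a 2-chlorophenyl or 2-fluorophenyl would lose as much, and how a plain phenyl would compare.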